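Swapping the aryl group: from compound 3 to compound 4

A few compounds are considered here, and "the series" means these few. Any claim that something is new, unique, unknown or untested is made for them only; others in the source may bear on it.

Compound 1, `Cc1cnc(Nc2ccc3[nH]ncc3c2)nc1-c1ccc(OC(F)(F)F)cc1`: 125 nM
Compound 2, `Cc1ccccc1C(=O)Nc1ccc(Nc2ncc(C)c(-c3ccc(OC(F)(F)F)cc3)n2)cc1`: 42.1 nM
Compound 3, `Cc1cnc(Nc2ccc(C(=O)Nc3c(C)cccc3C)cc2)nc1-c1ccccc1OC(F)(F)F`: > 500 nM

These three compounds were tested in an assay on NIH3T3 cells for inhibition of Sonic hedgehog protein (Mus musculus), read by a luciferase reporter, with a stated time of 48 h; on this read-out higher numbers stand for weaker inhibition and lower numbers for stronger inhibition. Compound 1 gives 125 nM and compound 2 gives 42.1 nM. For compound 3 the assay reports only a limit, > 500 nM, rather than a number. Compound 3 therefore stands at the limit of > 500 nM in this assay, at which 1 of the 3 values shown sits, the weak end of the three values shown.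

Compound 4, `Cc1cnc(Nc2ccc(C(=O)Nc3c(C)cccc3C)cc2)nc1-c1ccc(F)cc1`, has not yet been measured. It differs from compound 3 in one place: 4-fluorophenyl in place of 2-(trifluoromethoxy)phenyl on an aromatic carbon. Within the data shown here, no pair of measured compounds differs by this same change, so the expectation rests on where compound 3 sits and on the fact that its value is a limit, which leaves the size of any shift open. The step from compound 3 to compound 4 is expected to be an at least 2.5-fold lower number from compound 3 to compound 4 (0.39 log units; beyond the scatter), toward stronger inhibition. Compound 4 is estimated at 200 nM, with a likely range from 40 nM to 1000 nM.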

Compound 4, half-maximal inhibitory concentration: 2.2 nM
Beside the measured number, compound 4's estimate is 91-fold (1.96 log units) above it, and the stated range ends above it.
By their numbers in this assay, from the lowest: compound 4; then compound 2; then compound 1. At a limit, above all of these: compound 3.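

In this assay, the aryl group on the carbon next to the ring nitrogen and ortho to a methyl group has a very large influence: putting 4-fluorophenyl in place of 2-(trifluoromethoxy)phenyl gives an at least 220-fold lower number from compound 3 to compound 4 (2.35 log units; beyond the scatter). No other pair shown differs at this position alone, so this is the first direct reading of how far a change here can move the result. The true size of the step may be larger still, because compound 3 has only a limit rather than a number: the limit of > 500 nM in this assay, at which 1 of the 4 values shown sits.

This one step cannot separate the identity of the group on the phenyl ring from its place, since the two groups differ in both. Also open, on these data alone, is how a phenyl ring carrying an amine or a carboxylic acid would behave at this position.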